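Working notes: halogenated benzyl variants of the shared core

This account rests on a few compounds, and the source may have more. Where it says the series, first, only, none or still open, it means among the compounds named here.

Compound 3 `O=c1ccoc2cc(OCc3cn(Cc4ccc(Br)cc4)nn3)ccc12` was run in an ADME assay on L02 cells (Homo sapiens) for cytotoxicity, read by MTT assay, with a stated time of 48 h; a higher number here means a weaker inhibitor, a lower number a stronger inhibitor. In this assay compound 3 gives only a limit, > 300000 nM. Compound 1 `O=c1ccoc2cc(OCc3cn(Cc4cccc(Br)c4)nn3)ccc12` likewise gives only a limit in this assay, > 300000 nM. Compound 2 `O=c1ccoc2cc(OCc3cn(Cc4ccc(F)cc4)nn3)ccc12` also gives only a limit in this assay, > 300000 nM. For the measured compounds named here, all three values sit at the limit of > 300000 nM in this assay, at which 3 of the 3 values shown sit, so no step among them can be read: a step that the two limits leave unreadable from compound 1 to compound 2, a step that the two limits leave unreadable from compound 1 to compound 3, and a step that the two limits leave unreadable from compound 2 to compound 3. Compound 4 `O=c1ccoc2cc(OCc3cn(Cc4ccccc4Cl)nn3)ccc12` differs from compound 3 by 2-chlorophenyl in place of 4-bromophenyl on a saturated chain carbon bound to an aromatic nitrogen. The measured steps bear on this change only in that every exchange of the halogenated phenyl group, whether of the halogen itself or of the whole group as named, left the value at the limit; none has a readable size. No step beyond the scatter is therefore expected in this assay, and compound 4 is expected to stay at the limit as well. The expected step from compound 3 to compound 4 is a step that the limit leaves unreadable from compound 3 to compound 4. For compound 4 the estimate in this assay is 350000 nM, in the range 120000 nM to 1500000 nM.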

Compound 4, half-maximal inhibitory concentration: > 300000 nM
Compound 4: only a limit was reported (the forecaster's own chance of this, stated with the estimate: 85%); the middle value is on the limit's open side.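

In this assay compound 4 gives only a limit, > 300000 nM. For the compounds shown here, no step from compound 1, compound 2 or compound 3 to compound 4 can be read: the limit of > 300000 nM in this assay, at which 4 of the 4 values shown sit. The compounds shown leave open whether any exchange of the halogenated phenyl group changes the value, as none gives a number.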